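A Methyl Added Where the Nitrogen Is Double-Bonded

This account rests on a few compounds, and the source may have more. Where it says the series, first, only, none or still open, it means among the compounds named here.

Compound 3 `C/N=C(\S)NCCCCn1nc(-c2ccccc2)ccc1=O` is tested in a functional assay on the whole organism (stomach) with Rattus norvegicus as the target (a lower number here means that less compound is needed, a higher number that more compound is needed for the effect), where compound 3 gives 28.9 mg/kg. Compound 2 `C/N=C(\S)NCCCCCn1nc(-c2ccccc2)ccc1=O` gives 35.3 mg/kg, and the difference is a 1.2-fold lower number from compound 2 to compound 3 (0.09 log units; within the scatter). Compound 1 `C/N=C(/NC#N)NCCCn1nc(-c2ccccc2)ccc1=O` gives > 100 mg/kg, which is a limit of the assay rather than a number (the limit of > 100 mg/kg in this assay, at which 1 of the 3 values shown sits). The measured steps show an at least 2.8-fold lower number from compound 1 to compound 2 (0.45 log units; beyond the scatter) and an at least 3.4-fold lower number from compound 1 to compound 3 (0.53 log units; beyond the scatter). Of the two numbers shown, compound 3 has the lowest, but its gap to compound 2 lies within the scatter, so the two cannot be ranked.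

Compound 4 `CC/N=C(\S)NCCCCn1nc(-c2ccccc2)ccc1=O` differs from compound 3 by methyl in place of hydrogen on a saturated chain carbon bound to a double-bonded nitrogen, which read one bond further out is methyl to ethyl. Going by the values given here, none of the measured steps changes this position; the only small change elsewhere, from compound 2 to compound 3, stayed within the scatter. A step within the scatter in this assay is therefore expected. Compound 4 is expected to give 30 mg/kg, between 12 mg/kg and 75 mg/kg, a step of a 1.0-fold higher number from compound 3 to compound 4 (0.02 log units; within the scatter).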

Compound 4, dose for half-maximal effect: 37.2 mg/kg
Compound 4: the middle estimate sits 1.2-fold (0.09 log units) below what was measured; low and high end bracket the measured number.
By their numbers in this assay, from the lowest: compounds 3, 2 and 4 (each within the scatter of the next). At a limit, above all of these: compound 1.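

Going from hydrogen to methyl on a saturated chain carbon bound to a double-bonded nitrogen, this assay shows a 1.3-fold higher number from compound 3 to compound 4 (0.11 log units; within the scatter), the first measured step at this position, so this added methyl produces no change that can be told apart from the usual scatter. The comparison with the other sulfur-bearing compound gives the same picture, with a 1.1-fold higher number from compound 2 to compound 4 (0.02 log units; within the scatter), so compound 2, compound 3 and compound 4 cannot be ranked. There remains an at least 2.6-fold lower number from compound 1 to compound 4 (0.42 log units; beyond the scatter), and this step rests on a limit, not a number: the limit of > 100 mg/kg in this assay, at which 1 of the 4 values shown sits.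

Going by these compounds, only methyl in place of hydrogen has been seen here, so whether a propyl group or a longer chain at this carbon would stay within the scatter remains open. Equally open, on these data alone, is what a phenyl ring or an amine at this place would do.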